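The source may report more compounds than this note shows. Statements on the series, on what has been measured and on what is new or still open speak of the compounds shown alone.

For the measured compounds named here, in an assay on HEK293 cells for displacement of a labelled ligand from Melanocortin receptor 4 (Homo sapiens) (on this read-out lower numbers stand for stronger inhibition and higher numbers for weaker inhibition), compound 2 `CC(C)C[C@H](N)c1cc(C(F)(F)F)ccc1N1CCN(C(=O)CCC2CCCCC2)CC1` gives 5700 nM, the highest of the three numbers measured so far. Compound 1 `Cc1ccc(CC(C)C(=O)N2CCN(c3ccc(C(F)(F)F)cc3[C@@H](N)CC(C)C)CC2)cc1C` gives 240 nM and compound 3 `CC(C)C[C@H](N)c1ccccc1N1CCN(C(=O)[C@H](C)Cc2ccc(Cl)cc2F)CC1` gives 67 nM. Going by the values given here, the only measured step that reaches compound 2 is a 24-fold higher number from compound 1 to compound 2 (1.38 log units; beyond the scatter), a change on the same carbonyl-bearing chain that is altered once more in compound 4 `CC(C)C[C@H](N)c1cc(C(F)(F)F)ccc1N1CCN(C(=O)CCC(N)=O)CC1`, where the difference from compound 2 is carbamoyl in place of cyclohexyl on a saturated chain carbon, two bonds along the chain from a carbonyl carbon. Among the compounds with values here, no measured pair exchanges a carbon ring for a carbamoyl, so that earlier step offers only the hint that what sits on this chain moves this assay strongly. Compound 4 is therefore expected to read about 12000 nM, somewhere between 3500 nM and 40000 nM, which would be an estimated step of a 2.1-fold higher number from compound 2 to compound 4 (0.32 log units; beyond the scatter).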

Compound 4, inhibition constant: > 10000 nM
Compound 4 ended at the assay's limit (the forecaster's own chance of this, stated with the estimate: 30%); the middle value lies beyond the limit too.
By their numbers in this assay, from the lowest: compound 3; then compound 1; then compound 2. At a limit, above all of these: compound 4.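

For compound 4 the reading is a limit of the assay and not a number: the limit of > 10000 nM in this assay, at which 1 of the 4 values shown sits. Carbamoyl in place of cyclohexyl on this saturated chain carbon gives an at least 1.7-fold higher number from compound 2 to compound 4 (0.24 log units; that floor lies within the scatter), so this floor does not separate the two compounds. Putting 2-carbamoylethyl in place of 1-(3,4-dimethylbenzyl)ethyl on a carbonyl carbon gives a firmer result, an at least 41-fold higher number from compound 1 to compound 4 (1.61 log units; beyond the scatter), so the carbamoyl-ended chain does not recover the reading of the branched benzyl-bearing chain. As far as these compounds go, how far compound 4 truly lies past its limit stays open. So does how an amine or a carboxylic acid would read at this chain carbon.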